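Swapping cyclohexyl for benzyl on the imidazole nitrogen

The source may hold more compounds than are shown below. What is called first, only, known or untested is meant among the compounds shown, and "the series" means these compounds.

Measured compounds:
Compound 1, `O=Cc1ccc(-c2cn3ccnc3c(-c3ccc4ncn(C5CCCCC5)c4c3)n2)cc1`: 54.5%
Compound 2, `Brc1ccc(-c2cn3ccnc3c(-c3ccc4ncn(C5CCCCC5)c4c3)n2)cc1`: 8.38%
Compound 3, `COc1ccccc1-c1cn2ccnc2c(-c2ccc3ncn(C4CCCCC4)c3c2)n1`: 2.79%

In a functional assay on NCI-H23 cells (Homo sapiens) for inhibition, read by sulforhodamine B assay, with a stated time of 48 h, tested at 10 uM (on this read-out lower numbers stand for less inhibition and higher numbers for more inhibition at the one concentration tested (going by the name of the read-out)), compound 1 stands highest of the three numbers. The step of a number 46.1 percentage points lower from compound 1 to compound 2 (beyond the scatter) and the step of a number 51.7 percentage points lower from compound 1 to compound 3 (beyond the scatter) both lie beyond the scatter, whereas a number 5.6 percentage points lower from compound 2 to compound 3 (within the scatter) does not.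

Compound 4, `O=Cc1ccc(-c2cn3ccnc3c(-c3ccc4ncn(Cc5ccccc5)c4c3)n2)cc1`, has not been measured. It differs from compound 1 by benzyl in place of cyclohexyl on an aromatic nitrogen. Among the measured compounds shown here, none of the measured steps touches this position; all three concern the other aromatic group, so they give no direct guide. With nothing pointing in either direction, compound 4 is expected to stay close to compound 1, and the step of a number 4.5 percentage points lower from compound 1 to compound 4 (within the scatter) is estimated to lie within the scatter, with a wide margin of uncertainty. Compound 4 is therefore estimated at 50%, in the range 20% to 75%.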

Compound 4, a percentage reported as inhibition, at one concentration (the size of the read-out at that concentration, not a potency): 54.5%
Beside the measured number, compound 4's estimate is 4.5 percentage points below it; the range from low to high includes it.
By their numbers in this assay, from the lowest: compounds 3 and 2 (each within the scatter of the next); then compounds 1 and 4 (each within the scatter of the next).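

In this assay, benzyl in place of cyclohexyl on the aromatic nitrogen gives no change at the digits printed from compound 1 to compound 4 (within the scatter). Among the compounds shown here, the earlier compounds varied only the other aromatic group, so this is the first sign that, with the 4-formylphenyl group in place, this read-out does not separate a non-aromatic ring from an aromatic one at this nitrogen. Nothing available explains why the two groups read alike. Still open, from the compounds shown here alone, is whether a longer chain or an amine on this nitrogen would read the same. Also open, going by these compounds, is whether benzyl would read the same alongside the 4-bromophenyl or 2-methoxyphenyl group.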